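Nitro for amino on a methylated thione core

This account rests on a few compounds, and the source may have more. Where it says the series, first, only, none or still open, it means among the compounds named here.

In a functional assay on the whole organism with Mus musculus as the target (on this read-out lower numbers stand for an effect already at smaller amounts and higher numbers for an effect only at larger amounts of compound), compound 1 `COc1cc2c(cc1OC)C(c1ccc(N)cc1)=NN=C(S)C2` gives 3.3 umol/kg. Compound 2 `COc1cc2c(cc1OC)C(c1ccc([N+](=O)[O-])cc1)=NN=C(S)C2` carries nitro in place of amino on an aromatic carbon and in this assay compound 2 gives 69.8 umol/kg; the step of a 21-fold higher number from compound 1 to compound 2 (1.33 log units; beyond the scatter). Compound 3 `COc1cc2c(cc1OC)C(c1ccc(N)cc1)=NN(C)C(=S)C2` differs from compound 1 in its core, a difference that is not broken down here, and in this assay compound 3 gives 20.3 umol/kg. Compound 4 `COc1cc2c(cc1OC)C(c1ccc([N+](=O)[O-])cc1)=NN(C)C(=S)C2` is not yet measured; it differs from compound 3 by nitro in place of amino on an aromatic carbon, the same change as from compound 1 to compound 2, at the same place. Because a 21-fold higher number from compound 1 to compound 2 (1.33 log units; beyond the scatter) is large, the step of a 15-fold higher number from compound 3 to compound 4 (1.17 log units; beyond the scatter) is expected to be of similar size, though the change of core between compound 1 and compound 3 makes the carry-over uncertain. Compound 4 is estimated at 300 umol/kg in this assay, within a range from 80 umol/kg to 1200 umol/kg.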

Compound 4, dose for half-maximal effect: 81.5 umol/kg
Beside the measured number, compound 4's estimate is 3.7-fold (0.57 log units) above it; the measured number falls inside the stated range.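

On the core of compound 3, nitro in place of amino gives a 4.0-fold higher number from compound 3 to compound 4 (0.60 log units; beyond the scatter), the same direction as on the core of compound 1. In this assay, the direction of the change therefore carries over between these two cores, but its size does not: the same change on two cores in this assay, a 21-fold higher number (1.33 log units; beyond the scatter) from compound 1 to compound 2 and a 4.0-fold higher number (0.60 log units; beyond the scatter) from compound 3 to compound 4, 5.3-fold (0.72 log units) apart, beyond the scatter of two such steps

With one pair on each core, this shows agreement in direction in only two cases; it does not show what sets the different sizes or how the change would behave on a further core.

Open, going by these compounds, is whether a dimethylamino or an acetamide at the same place would follow amino or nitro on each core. Also open, on these data alone, is how an ethyl in place of the core methyl would affect the step.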